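Amide partner swap at the carbonyl carbon of compound 1

The source may report more compounds than this note shows. Statements on the series, on what has been measured and on what is new or still open speak of the compounds shown alone.

Compounds measured so far:
compound 1, `O=C(C1CCCCC1)N1CC(c2nc(-c3cccc(F)c3)no2)C1`, 1000 nM
compound 2, `O=C(C1CCC(C(F)(F)F)CC1)N1CC(c2nc(-c3cccc(F)c3)no2)C1`, 680 nM
compound 3, `Cc1cccc(-c2noc(C3CN(S(=O)(=O)c4ccc(F)cc4)C3)n2)c1`, > 10000 nM
Not yet measured: compound 4, `O=C(c1ccc(Cl)cc1)N1CC(c2nc(-c3cccc(F)c3)no2)C1`.

In an assay on HEK293 cells for positive allosteric modulation of metabotropic glutamate receptor 5 (Homo sapiens), read by FLIPR (a higher number here means that more compound is needed for the effect, a lower number that less compound is needed), compound 1 gives 1000 nM, the highest of the two numbers reported. Compound 2 gives 680 nM; a 1.5-fold lower number from compound 1 to compound 2 (0.17 log units; within the scatter), so the two lie together. Compound 3 is reported only as a limit of the assay, > 10000 nM; (the limit of > 10000 nM in this assay, at which 1 of the 3 values shown sits).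

The change to compound 4: 4-chlorophenyl in place of cyclohexyl on a carbonyl carbon. A six-membered aromatic ring of carbon only thus stands where a six-membered non-aromatic ring of carbon only stood. Among the compounds with values here, no measured step touches this kind of exchange. Within the data shown here, the one step on record, from compound 1 to compound 2, alters a substituent on the saturated ring and stays within the scatter, which says nothing about removing the ring itself. Among the measured compounds shown here, compound 3 differs from compound 1 in more than one place and gives no single step.

For the measured compounds named here, with no guiding step, the expectation for compound 4 is a change no larger than the scatter, a 1.1-fold lower number from compound 1 to compound 4 (0.05 log units; within the scatter). Compound 4 is estimated at 900 nM, with a range from 250 nM to 4000 nM.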

Compound 4, half-maximal effective concentration: 2500 nM
Beside the measured number, compound 4's estimate is 2.8-fold (0.44 log units) below it; the measured number falls inside the stated range.
By their numbers in this assay, from the lowest: compounds 2 and 1 (each within the scatter of the next); then compound 4. At a limit, above all of these: compound 3.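

In this assay the substituent on the carbonyl carbon proves able to shift the number: 4-chlorophenyl in place of cyclohexyl gives a 2.5-fold higher number from compound 1 to compound 4 (0.40 log units; beyond the scatter), whereas the change on the saturated ring gave a 1.5-fold lower number from compound 1 to compound 2 (0.17 log units; within the scatter). The step is modest, and compound 4 still gives a measured number, so an aromatic ring of carbon only at this place leaves a readable effect, though the saturated cyclohexyl of compound 1 has the lower number. Nothing shown gives a cause for this step.

The compounds shown do not separate the effect of the aromatic ring from that of the chlorine, and a plain phenyl group on the carbonyl carbon would bear on this. As far as these compounds go, how a ring carrying an amine or a carboxylic acid, or an open alkyl chain, would read at this place also stays open.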